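Amide tail variation: notes on the next analogue

The source may report more compounds than this note shows. Statements on the series, on what has been measured and on what is new or still open speak of the compounds shown alone.

Measured so far in a functional assay on NCI-H1581 cells (Homo sapiens) for antiproliferative activity, read by CCK-8 assay, with a stated time of 72 h; on this read-out lower numbers stand for stronger inhibition and higher numbers for weaker inhibition:
compound 1 `COc1cc(OC)c(Cl)c(-c2ccc3c(NC(=O)c4ccc(N5CCCCC5)cc4)n[nH]c3n2)c1Cl` — 558 nM
compound 2 `COc1cc(OC)c(Cl)c(-c2ccc3c(NC(=O)c4ccc(C5CCN(C)CC5)cc4)n[nH]c3n2)c1Cl` — 8.2 nM
compound 3 `COc1cc(OC)c(Cl)c(-c2ccc3c(NC(=O)c4ccc(N5CCN(C)CC5)c(Cl)c4)n[nH]c3n2)c1Cl` — 191 nM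

Compound 2 stands lowest of the three, ahead of compound 3 by a gap beyond the scatter and of compound 1 by the larger gap a 68-fold lower number from compound 1 to compound 2 (1.83 log units; beyond the scatter). Compound 4 `COc1cc(OC)c(Cl)c(-c2ccc3c(NC(=O)c4ccc(N5CCNCC5)cc4)n[nH]c3n2)c1Cl` carries the change (piperazin-1-yl in place of 1-methylpiperidin-4-yl on an aromatic carbon). Going by the values given here, the only step that bears on it is a 68-fold lower number from compound 1 to compound 2 (1.83 log units; beyond the scatter), since the entering piperazin-1-yl resembles the piperidin-1-yl of compound 1 more than the 1-methylpiperidin-4-yl it replaces. A higher number than compound 2 is therefore expected, though the value of compound 3 suggests the move need not run all the way back to compound 1. Compound 4 is estimated at 60 nM (range 15 nM to 250 nM), a step of a 7.3-fold higher number from compound 2 to compound 4 (0.86 log units; beyond the scatter).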

Compound 4, half-maximal inhibitory concentration: 1.4 nM
The estimate for compound 4 lay 43-fold (1.63 log units) above the measured number, outside the stated range (below it).
By their numbers in this assay, from the lowest: compound 4; then compound 2; then compound 3; then compound 1.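

In this assay, attachment of the ring through nitrogen does not by itself mark the weak end of the series: piperazin-1-yl is also joined through nitrogen, yet it gives a 400-fold lower number from compound 1 to compound 4 (2.60 log units; beyond the scatter). The same group also improves on the carbon-linked 1-methylpiperidin-4-yl, with a 5.9-fold lower number from compound 2 to compound 4 (0.77 log units; beyond the scatter). No measurement at hand accounts for either step. Still open, as far as these compounds go, is whether a morpholin-4-yl, with oxygen in place of the second ring nitrogen, keeps this level, and whether a piperidin-4-yl matches piperazin-1-yl.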